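The compounds below may be only part of what the source reports. "The series", "measured", "known", "first", "only" and "open" are said of these compounds alone.

Compounds measured so far in a functional assay on HEp-2 cells (Homo sapiens) for antiproliferative activity, read by MTT assay, with a stated time of 72 h; on this read-out higher numbers stand for weaker inhibition and lower numbers for stronger inhibition:

- compound 1 `O=c1cc(CSC(=S)N2CCCCC2)oc2cc(Cl)ccc12`: 1600 nM
- compound 2 `O=c1cc(CSC(=S)N2CCCCC2)oc2ccccc12`: 12000 nM
- compound 3 `O=c1c(CSC(=S)N2CCOCC2)coc2cc(Cl)ccc12`: 900 nM

Among these three numbers compound 1 stands second highest. Its nearest neighbour is compound 3, whose number lies within the scatter of that of compound 1, so no order between the two can be read. For the measured compounds named here, its furthest neighbour is compound 2: the only single-site step measured here, a 7.5-fold higher number from compound 1 to compound 2 (0.88 log units; beyond the scatter), comes from hydrogen in place of chloro on an aromatic carbon, and it lies beyond the scatter.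

Compound 4 `O=c1cc(CSC(=S)N2CCOCC2)oc2cc(Cl)ccc12` keeps the chloro of compound 1 and differs from it in one place: morpholin-4-yl in place of piperidin-1-yl on a thiocarbonyl carbon. Going by the values given here, no measured step changes this ring, so the one step that exists, from compound 1 to compound 2, says nothing about it. Compound 3 does carry the morpholin-4-yl ring, but it differs from compound 1 in more than one place, so only its value can be set beside that of compound 1, and the two lie within the scatter. The expectation for compound 4 is therefore a step of about a 1.2-fold lower number from compound 1 to compound 4 (0.09 log units; within the scatter) in this assay, not beyond the scatter in either direction. Compound 4 is estimated at 1300 nM, with a range from 500 nM to 3500 nM.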

Compound 4, half-maximal inhibitory concentration: 20600 nM
Estimate against measurement, compound 4: 16-fold (1.20 log units) below, and the stated range ends below it.
By their numbers in this assay, from the lowest: compounds 3 and 1 (each within the scatter of the next); then compounds 2 and 4 (each within the scatter of the next).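

In this assay, the ring on the thiocarbonyl carbon proves to be a sensitive site, since morpholin-4-yl in place of piperidin-1-yl gives a 13-fold higher number from compound 1 to compound 4 (1.11 log units; beyond the scatter) on the otherwise unchanged chloro-bearing core. Both rings are six-membered and have 6 heavy atoms, so the step arises without any change in ring size, while the entering ring has 2 hetero atoms and 1 hydrogen-bond acceptor against 1 hetero atom and 0 hydrogen-bond acceptors in the ring that leaves. Compound 1 therefore now has two single-site steps beyond the scatter, this one on the ring and a 7.5-fold higher number from compound 1 to compound 2 (0.88 log units; beyond the scatter) on the aromatic carbon, but no measurement here explains why the ring change has this effect.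

As far as these compounds go, compound 3 carries the same morpholin-4-yl ring and gives 900 nM in this assay, yet without its piperidin-1-yl partner, it is open whether the ring change has a similar effect on that core. Also open, from the compounds shown here alone, is how other rings on the thiocarbonyl carbon, such as pyrrolidin-1-yl or 4-methylpiperazin-1-yl, would compare with piperidin-1-yl on the core of compound 1.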